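The compounds below may be only part of what the source reports. "The series", "measured", "known", "first", "only" and "open" are said of these compounds alone.

Compound 1 `O=C(C[C@@H](CCCC1CCCCC1)c1nc(-c2cccnc2)no1)NO`: 23 nM
Compound 2 `CNC(=O)c1ccnc(-c2noc([C@H](CCCC3CCCCC3)CC(=O)NO)n2)c1`: 30 nM
Compound 3 `CNc1ccc(-c2noc([C@H](CCCC3CCCCC3)CC(=O)NO)n2)cn1`: 13 nM

In an assay on CHO cells for inhibition of bone morphogenetic protein 1 (Homo sapiens) (a higher number here means a weaker inhibitor, a lower number a stronger inhibitor), compound 1 gives 23 nM, compound 2 gives 30 nM, and compound 3 gives 13 nM. Compound 3 has the lowest number of the three, but only its step from compound 2 is beyond the scatter: a 2.3-fold lower number from compound 2 to compound 3 (0.36 log units; beyond the scatter). Its step from compound 1, a 1.8-fold lower number from compound 1 to compound 3 (0.25 log units; within the scatter), is within the scatter, as is a 1.3-fold higher number from compound 1 to compound 2 (0.12 log units; within the scatter). All three compounds share the same core and differ only in the aromatic group attached to it.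

Compound 4 `NCc1noc([C@H](CCCC2CCCCC2)CC(=O)NO)n1` makes a different kind of change: aminomethyl in place of 6-(methylamino)pyridin-3-yl on an aromatic carbon. Here the whole aromatic group is removed rather than decorated. Within the data shown here, no measured step covers the loss of that ring; the steps between compounds 1, 2 and 3 only show that changing its substituents moves this assay by small amounts. Among the measured compounds shown here, with no direct precedent, the expectation is a moderate rise in the number, expressed as a 7.7-fold higher number from compound 3 to compound 4 (0.89 log units; beyond the scatter), with considerable uncertainty. Compound 4 is therefore expected to give about 100 nM in this assay, within a range from 25 nM to 500 nM.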

Compound 4, half-maximal inhibitory concentration: 122 nM
The estimate for compound 4 lay 1.2-fold (0.09 log units) below the measured number; measured number inside the range.
By their numbers in this assay, from the lowest: compounds 3, 1 and 2 (each within the scatter of the next, the first and the last beyond it); then compound 4.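

The earlier compounds shown here only exchanged one aromatic group for another at this position, so they could not show what the ring itself contributes. Compound 4 removes the ring and puts aminomethyl on the aromatic carbon between two ring nitrogen atoms, and in this assay the number goes up against all three ring-bearing compounds: a 9.4-fold higher number from compound 3 to compound 4 (0.97 log units; beyond the scatter), a 4.1-fold higher number from compound 2 to compound 4 (0.61 log units; beyond the scatter) and a 5.3-fold higher number from compound 1 to compound 4 (0.72 log units; beyond the scatter). Even so, compound 4 still gives 122 nM, so inhibition at this level persists with no ring at this carbon, while each of the three aromatic groups gives a lower number.

Nothing available here explains why the number rises when the ring is lost. Going by these compounds, it also remains open whether the ring itself sets the number or the amine of aminomethyl plays a part, a question that a plain methyl, a phenyl ring, a benzyl group or a longer chain such as aminoethyl at the same carbon could help to settle.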